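Trimming the benzyl from a piperidine-bearing triazine

The source may hold more compounds than are shown below. What is called first, only, known or untested is meant among the compounds shown, and "the series" means these compounds.

Compound 1, `CC(=O)N1CCN(c2nc(Nc3ccc(C#N)c(C(F)(F)F)c3)nc(Oc3ccnc4ccccc34)n2)CC1`, in a functional assay on DU-145 cells (Homo sapiens) for cytotoxicity, read by sulforhodamine B assay, with a stated time of 48 h (on this read-out lower numbers stand for stronger inhibition of growth and higher numbers for weaker inhibition of growth), gives > 100000 nM.
Compound 2, `N#Cc1ccc(Nc2nc(Oc3ccnc4ccccc34)nc(N3CCC(Cc4ccccc4)CC3)n2)cc1C(F)(F)F`, in this assay gives > 100000 nM.

For compound 1 this figure is a limit of the assay, not a number. For compound 2 the value is likewise a limit of the assay. Both measurements thus sit at the limit of > 100000 nM in this assay, at which 2 of the 2 values shown sit, so compound 2 stands at the limit and no real growth inhibition has been resolved for it.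

Compound 3, `N#Cc1ccc(Nc2nc(Oc3ccnc4ccccc34)nc(N3CCCCC3)n2)cc1C(F)(F)F`, has not yet been measured in this assay. It differs from compound 2 in one place: hydrogen in place of benzyl on a saturated ring carbon. No measured step of this kind exists among the compounds shown, so no size or direction can be drawn from the data. Since compound 2 gives only > 100000 nM, the expected change a step that the limit leaves unreadable from compound 2 to compound 3 is judged to stay within the scatter. Compound 3 is therefore estimated at 150000 nM, with an expected range from 30000 nM to 1000000 nM.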

Compound 3, concentration for total growth inhibition: > 100000 nM
Compound 3: a limit, no number; the forecaster's own chance of this, stated with the estimate: 75%; the middle value does not contradict the limit.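

Compound 3, like compound 1 and compound 2, gives only a limit in this assay, so no step among these three compounds can be read: the limit of > 100000 nM in this assay, at which 3 of the 3 values shown sit. The compounds shown leave open whether any change to this group on the shared core can produce measurable growth inhibition.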